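The source may hold more compounds than are shown below. What is called first, only, known or untested is meant among the compounds shown, and "the series" means these compounds.

In a functional assay on MCF7 cells (Homo sapiens) for inhibition, read by MTT assay, with a stated time of 48 h, tested at 10 uM (a higher number here means more inhibition of growth at the concentration tested, a lower number less inhibition of growth), compound 1 `Cc1cc(=O)c2c(O)c(CN3CCCC3CO)c(O)c([C@H]3CCN(C)C[C@H]3O)c2o1` gives 22% and compound 2 `Cc1cc(=O)c2c(O)c(CN3CCCC3C(=O)O)c(O)c([C@H]3CCN(C)C[C@H]3O)c2o1` gives 21%. Compound 3 `Cc1oc2c([C@H]3CCN(C)C[C@H]3O)c(O)cc(O)c2c(=O)c1C(O)c1ccc(Cl)cc1` gives 6%, the lowest of the three numbers, with the other two beyond the scatter above it. Compound 4 `Cc1oc2c([C@H]3CCN(C)C[C@H]3O)c(O)cc(O)c2c(=O)c1C(O)c1ccccc1Br` differs from compound 3 in one group: 2-bromophenyl in place of 4-chlorophenyl on a saturated chain carbon bound to an aromatic carbon and an oxygen on a saturated carbon. Going by the values given here, the only measured step, a number 1 percentage points lower from compound 1 to compound 2 (within the scatter), places carboxy in place of hydroxymethyl on a saturated ring carbon, a different part of the molecule, so it offers little guidance here. Among the compounds with values here, with no measured step on this group, the expectation stays close to compound 3 at 6%. The expected step is a number 3 percentage points higher from compound 3 to compound 4 (within the scatter). For compound 4, the estimated value is 9%, with an expected range of 0% to 22%.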

Compound 4, percent growth inhibition at one concentration: 21%
Compound 4: the middle estimate sits 12 percentage points below what was measured, within the range that was stated.
By their numbers in this assay, from the lowest: compound 3; then compounds 2, 4 and 1 (each within the scatter of the next).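

In this assay the chain carbon carrying the aromatic ring proves sensitive to what it holds: 2-bromophenyl in place of 4-chlorophenyl gives a number 15 percentage points higher from compound 3 to compound 4 (beyond the scatter). This single swap changes both the halogen and its place on the phenyl ring, so the step cannot be credited to either alone. Nothing shown here gives a measured reason for the rise. The compounds shown leave open what 2-chlorophenyl or 4-bromophenyl would give at this carbon, which would separate those two changes, and what an amine on the phenyl ring would do.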